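The source may report more compounds than this note shows. Statements on the series, on what has been measured and on what is new or still open speak of the compounds shown alone.

The compounds here share a pattern in which an aromatic ring carrying a sulfonyl group is joined to a fused core that also bears a second aromatic ring. Compound 1 `O=S(=O)(c1cc(Cl)cc(Cl)c1)c1cnc2c(F)cccc2c1-c1ccc(F)cc1` and compound 2 `O=S(=O)(c1ccc(F)c(Cl)c1)c1cnc2c(F)cccc2c1-c1ccc(F)cc1` have one core; compound 3 `COc1ccc(-c2c(S(=O)(=O)c3cc(Cl)cc(Cl)c3)cnc3cc(F)ccc23)cc1` and compound 4 `COc1ccc(-c2c(S(=O)(=O)c3ccc(F)c(Cl)c3)cnc3cc(F)ccc23)cc1` have another. The difference between the two cores is not broken down here.

Compound 1 gives 1.01 mL/min in an ADME assay on microsomes from liver (Homo sapiens) for metabolic stability, tested at 2.5 uM; on this read-out higher numbers stand for fast clearance and lower numbers for slow clearance. Compound 2 differs from compound 1 in one place: 3-chloro-4-fluorophenyl in place of 3,5-dichlorophenyl on a sulfonyl sulfur In this assay compound 2 gives 0.19 mL/min. That change produced a 5.3-fold lower number from compound 1 to compound 2 (0.73 log units; beyond the scatter). Compound 3 gives 1 mL/min in this assay, and its value and that of compound 1 are within the usual scatter of each other, while compound 2 sits well apart from both.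

Compound 4 is not yet measured. It differs from compound 3 in the same way that compound 2 differs from compound 1: 3-chloro-4-fluorophenyl in place of 3,5-dichlorophenyl on a sulfonyl sulfur The surroundings of the change are the same in both pairs, a sulfonyl sulfur whose other neighbour is an aromatic carbon, so this is the same change seen again on the other core. On that basis the step from compound 3 to compound 4 in this assay is expected to be about as large as the earlier one, namely a 4.5-fold lower number from compound 3 to compound 4 (0.66 log units; beyond the scatter), because the same change gave a 5.3-fold lower number from compound 1 to compound 2 (0.73 log units; beyond the scatter). For the measured compounds named here, the value for compound 4 in this assay is therefore estimated at 0.22 mL/min, with a plausible range from 0.1 mL/min to 0.5 mL/min, the width reflecting that only one earlier example of the change is available.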

Compound 4, intrinsic clearance in a liver preparation (reported as CLH), per the amount of preparation that the assay uses: 1.08 mL/min
Beside the measured number, compound 4's estimate is 4.9-fold (0.69 log units) below it, outside the stated range (above it).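

On the core of compound 3, putting 3-chloro-4-fluorophenyl in place of 3,5-dichlorophenyl on a sulfonyl sulfur gives a 1.1-fold higher number from compound 3 to compound 4 (0.03 log units; within the scatter) in this assay, so the clear fall in clearance seen on the core of compound 1 does not appear on this core. The same change therefore behaves differently on the two cores: the same change on two cores in this assay, a 5.3-fold lower number (0.73 log units; beyond the scatter) from compound 1 to compound 2 and a 1.1-fold higher number (0.03 log units; within the scatter) from compound 3 to compound 4, 5.7-fold (0.76 log units) apart, beyond the scatter of two such steps. This shows that, in this series, a step measured on one core cannot simply be carried over to the other, but it does not show which feature of the cores lies behind the difference, and two pairs of compounds set no rule for any further core.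

On these data alone, the two cores differ in more than one place, so it remains open which part of them decides whether this change matters, and compounds whose cores differ in one place only would be needed to separate those parts. Also open, as far as these compounds go, is how clearance would respond on either core if the sulfonyl sulfur carried a phenyl ring bearing an amine or a carboxylic acid, or a longer chain instead of an aromatic ring.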